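Hydrogen in Place of Fluoro: A Half-Life Estimate

The source may report more compounds than this note shows. Statements on the series, on what has been measured and on what is new or still open speak of the compounds shown alone.

Compound 1 `CONC(=N)c1ccc(-c2ccc(-c3ccc(C(=N)NOC)cc3)c(F)c2)cc1`: > 1.5 h (a limit)
Compound 2 `CONC(=N)c1ccc(-c2ccc(-c3ccc(C(=N)NOC)cn3)cc2)nc1`: > 1.5 h (a limit)

Both readings come from an in vitro ADME assay on the whole organism (microsomes, liver, strain B6C3F1) for metabolic stability, with Mus musculus as the target (on this read-out higher numbers stand for a longer-lived compound and lower numbers for a shorter-lived compound), and neither is an exact number. Compound 1 stands at > 1.5 h in this assay, and this is a limit.

Compound 3 `CONC(=N)c1ccc(-c2ccc(-c3ccc(C(=N)NOC)cc3)cc2)cc1` has not yet been measured. It differs from compound 1 in a single place: hydrogen in place of fluoro on an aromatic carbon, with hydrogen in place of fluoro on an aromatic carbon.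

Going by the values given here, no pair of measured compounds shows this change on its own, so the data give no direct size for it. Among the compounds with values here, the only guide is that compound 1 and compound 2 share one reading, (the limit of > 1.5 h in this assay, at which 2 of the 2 values shown sit), and neither gives an exact half-life. On that basis, no shift beyond the usual scatter is expected, and no direction can be told. The expected change is a step that the limit leaves unreadable from compound 1 to compound 3, which is estimated to stay within the scatter. Compound 3 may well return only a limit too. For compound 3 the expected half-life is 1.8 h, within an estimated range of 1 h to 3.5 h.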

Compound 3, half-life: > 1.5 h
Compound 3 was reported as a limit; the forecaster's own chance of this, stated with the estimate: 75%; the middle value is on the limit's open side.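

Compound 1 and compound 3 both gave only a limit in this assay, so no step can be read for hydrogen in place of fluoro on an aromatic carbon: the limit of > 1.5 h in this assay, at which 3 of the 3 values shown sit.

The compounds shown leave open what the actual half-life of each one is in this assay, and whether hydrogen in place of fluoro changes it at all.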